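A Hydroxyphenyl Sulfonamide Following Three Analogues at the Limit

A few compounds are considered here, and "the series" means these few. Any claim that something is new, unique, unknown or untested is made for them only; others in the source may bear on it.

Compound 1, `COc1ccc(Cl)cc1S(=O)(=O)Nc1ccc(-c2nc3ccccc3o2)cc1`, gives in an assay on cells for inhibition of HSP60/HSP10 (Homo sapiens), with a stated time of 60 min (a higher number here means a weaker inhibitor, a lower number a stronger inhibitor), only the limit > 100000 nM.
Compound 2, `CCc1ccc(S(=O)(=O)Nc2ccc(-c3nc4ccccc4o3)cc2)cc1`, gives in this assay only the limit > 100000 nM.
Compound 3, `C=Cc1ccc(S(=O)(=O)Nc2ccc(-c3nc4ccccc4o3)cc2)cc1`, gives in this assay only the limit > 100000 nM.

Compound 3 thus stands at the limit of this assay, and the other two values shown stand there as well, as the limit of > 100000 nM in this assay, at which 3 of the 3 values shown sit, records. Compound 4, `O=S(=O)(Nc1ccc(-c2nc3ccccc3o2)cc1)c1cccc(O)c1`, differs from compound 3 in one place: 3-hydroxyphenyl in place of 4-vinylphenyl on a sulfonyl sulfur. The measured steps that bear on such a swap of the group on the sulfonyl sulfur are a step that the two limits leave unreadable from compound 1 to compound 2 and a step that the two limits leave unreadable from compound 1 to compound 3, and on the aromatic carbon a step that the two limits leave unreadable from compound 2 to compound 3. None of them can be read in size; both ends of each sit at the limit. Within the data shown here, nothing among the measured compounds shows that a 3-hydroxyphenyl on the sulfonyl sulfur would bring a reading inside the range of this assay, and nothing rules it out either. The expectation for compound 4 in this assay is therefore that it most likely also returns only a limit, the estimated step of a number no higher from compound 3 to compound 4 (the limit leaves the size open) being no more than scatter. Compound 4 is estimated at 100000 nM, within 20000 nM to 500000 nM.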

Compound 4, half-maximal inhibitory concentration: 62000 nM
Compound 4: the middle estimate sits 1.6-fold (0.21 log units) above what was measured, and the stated range covers the measured number.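

Among these compounds, with the 3-hydroxyphenyl on the sulfonyl sulfur, compound 4 is the only one of the four to give a number inside the range of this assay, so this position can carry a group that yields a readable value, which the earlier compounds did not show. The steps to it are an at least 1.6-fold lower number from compound 3 to compound 4 (0.20 log units; that floor lies within the scatter), an at least 1.6-fold lower number from compound 2 to compound 4 (0.20 log units; that floor lies within the scatter), and an at least 1.6-fold lower number from compound 1 to compound 4 (0.20 log units; that floor lies within the scatter); each is only a floor, while the steps among compound 1, compound 2 and compound 3 cannot be read. The other three compounds therefore give no measure of how the groups they carry compare with one another: the limit of > 100000 nM in this assay, at which 3 of the 4 values shown sit.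

Open, as far as these compounds go, is whether an amine or a carboxylic acid in place of the hydroxy group of the 3-hydroxyphenyl would also give a number inside the range of this assay. Also open, from the compounds shown here alone, is how much of the reading of compound 4 belongs to the hydroxy group itself, a question that a plain phenyl on the sulfonyl sulfur would address.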